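The compounds below may be only part of what the source reports. "The series", "measured", "known", "first", "only" and "open" are said of these compounds alone.

Measured so far in a functional assay on PC-3 cells (Homo sapiens) for antiproliferative activity, read by MTT assay, with a stated time of 72 h; a lower number here means a stronger inhibitor, a higher number a weaker inhibitor:
- compound 1 `CCN(CC)CCCNC(=O)c1ccc(C(CC)(CC)c2ccc(C#CC(O)(CC)CC)c(C)c2)n1CC`: 8500 nM
- compound 2 `CCN(CC)CCNC(=O)c1cc(C(CC)(CC)c2ccc(C#CC(O)(CC)CC)c(C)c2)cn1CC`: 5350 nM

Compound 2 at 5350 nM and compound 1 at 8500 nM lie within the scatter of each other, so this assay does not separate them. Going by the values given here, no two measured compounds differ in one place alone, so the series offers no measured step to lean on.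

Compound 3 `CCn1cc(C(CC)(CC)c2ccc(C#CC(O)(CC)CC)c(C)c2)cc1C(=O)NCCCN(C)C` has not yet been measured. It differs from compound 2 by a single change: (dimethylamino)methyl in place of diethylamino on a saturated chain carbon, two bonds along the chain from an amide-type nitrogen. Cut one bond further out, the same difference reads (2-(diethylamino)ethyl)amino to (3-(dimethylamino)propyl)amino.

No step beyond the scatter is expected in this assay, and no direction can be favoured. This expectation rests only on the narrow spread so far, with compound 1 at 8500 nM and compound 2 at 5350 nM, and that is thin support. The estimated size of the step is a 1.0-fold higher number from compound 2 to compound 3 (0.01 log units; within the scatter). For compound 3 the estimated value is 5500 nM, with an expected range of 2500 nM to 12000 nM.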

Compound 3, half-maximal inhibitory concentration: 15100 nM
Compound 3: the middle estimate sits 2.7-fold (0.44 log units) below what was measured; the measured number lies above the stated range.
By their numbers in this assay, from the lowest: compounds 2, 1 and 3 (each within the scatter of the next, the first and the last beyond it).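

In this assay, going by these compounds alone, the change from (2-(diethylamino)ethyl)amino to (3-(dimethylamino)propyl)amino gives a 2.8-fold higher number from compound 2 to compound 3 (0.45 log units; beyond the scatter), the first measured step and one that clears the scatter, though only modestly. The place on a saturated chain carbon, two bonds along the chain from an amide-type nitrogen, therefore responds to substitution in this assay, and here the two side chains are not interchangeable, with the higher number falling to the (3-(dimethylamino)propyl)amino chain of compound 3. Nothing measured on these compounds bears on what lies behind this step.

The single change alters both the alkyl groups on the terminal amine and the length of the chain, so the compounds shown cannot assign the step to either, and a 2-(dimethylamino)ethyl chain on the same core would help to separate the two. As far as these compounds go, whether a cyclic amine such as morpholine or pyrrolidine at the end of the chain would keep the lower number of compound 2 also remains open, as does whether the step carries over to the differently arranged core of compound 1.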